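From 2-bromophenyl to 4-acetylphenyl on a sulfonyl sulfur

The compounds below may be only part of what the source reports. "The series", "measured", "known", "first", "only" and "open" are said of these compounds alone.

Measured so far in a functional assay on HeLa cells (Homo sapiens) for cytotoxicity, read by sulforhodamine B assay (a higher number here means a weaker inhibitor, a lower number a stronger inhibitor), are three compounds
- compound 1 `CC(=O)c1ccc(S(=O)(=O)NC(C2=CC(=O)c3c(O)ccc(O)c3C2=O)C(C)C)cc1` with 3820 nM
- compound 2 `CC(NS(=O)(=O)c1cccc(Br)c1)C1=CC(=O)c2c(O)ccc(O)c2C1=O` with 6350 nM
- compound 3 `CC(NS(=O)(=O)c1ccccc1Br)C1=CC(=O)c2c(O)ccc(O)c2C1=O` with 6200 nM

Compound 3 lies within the scatter of both compound 1 and compound 2, so these three numbers show no real order. Compound 4 `CC(=O)c1ccc(S(=O)(=O)NC(C)C2=CC(=O)c3c(O)ccc(O)c3C2=O)cc1` differs from compound 3 by one change 4-acetylphenyl in place of 2-bromophenyl on a sulfonyl sulfur in which 4-acetylphenyl replaces 2-bromophenyl on a sulfonyl sulfur. Going by the values given here, the only measured step, a 1.0-fold lower number from compound 2 to compound 3 (0.01 log units; within the scatter), moved the bromine and bears on this change only loosely. Compound 1 already carries 4-acetylphenyl on a different side chain, and its 3820 nM sits within the scatter of compound 3. No step beyond the scatter is therefore expected in this assay, and an estimated 1.2-fold lower number from compound 3 to compound 4 (0.09 log units; within the scatter) follows. Compound 4 is expected at 5000 nM (expected range 2500 nM to 10000 nM).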

Compound 4, half-maximal inhibitory concentration: 5760 nM
Estimate against measurement, compound 4: 1.2-fold (0.06 log units) below; measured number inside the range.
By their numbers in this assay, from the lowest: compounds 1, 4, 3 and 2 (each within the scatter of the next).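

With a 1.1-fold lower number from compound 3 to compound 4 (0.03 log units; within the scatter) and a 1.1-fold lower number from compound 2 to compound 4 (0.04 log units; within the scatter) in this assay, 4-acetylphenyl on the sulfonyl sulfur gives a number that cannot be told apart from those of either bromophenyl compound. With a 1.5-fold higher number from compound 1 to compound 4 (0.18 log units; within the scatter) as well, methyl in place of isopropyl on the side chain also produces no readable difference when 4-acetylphenyl is present. Nothing measured here offers an explanation for these results.

As far as these compounds go, it remains open whether an amine or a carboxylic acid on the phenyl ring, or a longer chain in place of methyl or isopropyl, would move the number beyond the scatter.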